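Working notes on a series at its growth-inhibition limit

The compounds below may be only part of what the source reports. "The series", "measured", "known", "first", "only" and "open" are said of these compounds alone.

Measured in a functional assay on KB cells (Homo sapiens) for inhibition, read by sulforhodamine B assay, with a stated time of 72 h (on this read-out lower numbers stand for stronger inhibition of growth and higher numbers for weaker inhibition of growth), so far:
- compound 1 (`CN1CCN(C(=O)/C=C/c2ccncc2-c2ccc3ccccc3c2)CC1`) gives > 10000 nM as a limit
- compound 2 (`CCOC(=O)/C=C/c1ccncc1-c1ccc2[nH]ccc2c1`) gives > 10000 nM as a limit
- compound 3 (`O=C(CCc1ccncc1-c1ccc2ccccc2c1)N1CCOCC1`) gives > 10000 nM as a limit

Compound 1 gives > 10000 nM as its result, which is a limit and not a number. Going by the values given here, all three compounds stand at this limit (the limit of > 10000 nM in this assay, at which 3 of the 3 values shown sit), so no measured step is available. Compound 4 (`O=C(/C=C/c1ccncc1-c1ccc2ccccc2c1)N1CCOCC1`) is not yet measured and differs from compound 1 in one place (morpholin-4-yl in place of 4-methylpiperazin-1-yl on a carbonyl carbon), on a carbonyl carbon. Compound 3 also carries morpholin-4-yl, and its > 10000 nM is likewise a limit. The expected step of a number no higher from compound 1 to compound 4 (the limit leaves the size open) lies within the scatter, with no direction expected. For compound 4 the estimate is 10000 nM with an expected range of 3000 nM to 20000 nM in this assay and a report as a limit is likely.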

Compound 4, concentration for 50% growth inhibition: > 10000 nM
Compound 4: a limit, no number; the forecaster's own chance of this, stated with the estimate: 80%; the middle value lies on the limit itself.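

No new step can be read from compound 1 to compound 4, since both results are limits and not numbers: the limit of > 10000 nM in this assay, at which 4 of the 4 values shown sit.

The compounds shown leave open which structural change, if any, would give a measurable value in this series.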